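Compound 1 to compound 4: a shorter ether

The source may report more compounds than this note shows. Statements on the series, on what has been measured and on what is new or still open speak of the compounds shown alone.

Measured in a functional assay on A549 cells (Homo sapiens) for inhibition, read by colorimetric assay and MTT assay, with a stated time of 72 h; on this read-out higher numbers stand for weaker inhibition and lower numbers for stronger inhibition:
- compound 1 `C=CCCCCOc1ccccc1-c1cnc(OCCC=C)n1C`: 9000 nM
- compound 2 `C=CCCCCOc1ccc(OC)cc1-c1cnc(OCCC=C)n1C`: 43000 nM
- compound 3 `C=CCCCCCOc1ncc(-c2ccccc2OCCCCC=C)n1C`: 62000 nM

Compound 1 holds the lowest number of the three. Compound 4 `C=CCCOc1ncc(-c2ccccc2OC)n1C` differs from it by hydrogen in place of pent-4-en-1-yl on a saturated chain carbon bound to an oxygen on an aromatic ring, which also reads as (hex-5-en-1-yl)oxy to methoxy. Within the data shown here, no measured step changes that chain. Among the measured compounds shown here, two steps bear on it only indirectly: methoxy in place of hydrogen on an aromatic carbon gave a 4.8-fold higher number from compound 1 to compound 2 (0.68 log units; beyond the scatter), and pent-4-en-1-yl in place of vinyl gave a 6.9-fold higher number from compound 1 to compound 3 (0.84 log units; beyond the scatter). Both raised the number, so a modest rise in this assay is expected, with wide uncertainty. The expected step is a 2.8-fold higher number from compound 1 to compound 4 (0.44 log units; beyond the scatter). For compound 4 the estimate is 25000 nM, with an expected range from 7000 nM to 90000 nM.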

Compound 4, half-maximal inhibitory concentration: 22000 nM
Compound 4: the middle estimate sits 1.1-fold (0.06 log units) above what was measured, and the stated range covers the measured number.
By their numbers in this assay, from the lowest: compound 1; then compounds 4, 2 and 3 (each within the scatter of the next, the first and the last beyond it).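

In this assay, among these compounds, the change from (hex-5-en-1-yl)oxy to methoxy gives a 2.4-fold higher number from compound 1 to compound 4 (0.39 log units; beyond the scatter) as the first direct reading at this position. The step is modest but beyond the scatter, so removing the pent-4-en-1-yl group and its double bond raises the number without abolishing inhibition in this assay. No available evidence explains the rise.

On these data alone, how a saturated hexyl chain, an ethoxy group or a chain ending in an amine would read at this place remains open. As far as these compounds go, whether the chain's terminal double bond contributes separately from its length also remains open.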